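A few compounds are considered here, and "the series" means these few. Any claim that something is new, unique, unknown or untested is made for them only; others in the source may bear on it.

Compound 1, `Cc1ccc(S(=O)(=O)N2C=CNC(=O)[C@H]2CC(=O)N[C@@H]2CCCc3cc(CN(C)C)ccc32)cc1`, in an in vitro functional assay on cells for antagonist activity at B1 bradykinin receptor (Homo sapiens), read by luminescence and calcium flux, with a stated time of 2 h; on this read-out lower numbers stand for stronger inhibition and higher numbers for weaker inhibition: 0.21 nM
Compound 2, `Cc1ccc(S(=O)(=O)N2C=CNC(=O)[C@H]2CC(=O)N[C@@H]2CCCc3ccccc32)cc1`, in this assay: 3.3 nM
Compound 3, `Cc1ccc(S(=O)(=O)N2C=CNC(=O)[C@H]2CC(=O)N[C@@H]2CCC(O)c3ccccc32)cc1`, in this assay: 1.47 nM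

Compound 2 stands highest of the three numbers in this assay; compound 3 lies nearest, a 2.2-fold lower number from compound 2 to compound 3 (0.35 log units; beyond the scatter), and compound 1 furthest, with a 16-fold higher number from compound 1 to compound 2 (1.20 log units; beyond the scatter) when the change is read the other way.

Compound 4, `Cc1ccc(S(=O)(=O)N2C=CNC(=O)[C@H]2CC(=O)N[C@H]2CCN(C)CC2(C)C)cc1`, differs from compound 2 by a group of 9 heavy atoms (8 carbon, 1 nitrogen; one six-membered non-aromatic ring with 1 hetero atom) in place of a group of 10 heavy atoms (10 carbon; one six-membered non-aromatic ring of carbon only, one six-membered aromatic ring of carbon only), on an amide-type nitrogen. The measured step of a 16-fold higher number from compound 1 to compound 2 (1.20 log units; beyond the scatter) shows that removing a group that carried a nitrogen gave a large weakening; here a nitrogen-bearing ring enters. Among the compounds with values here, no measured step covers the loss of the aromatic ring. The step from compound 2 to compound 4 is therefore expected to be a modest lowering, a 2.2-fold lower number from compound 2 to compound 4 (0.34 log units; beyond the scatter). Compound 4 is estimated at 1.5 nM, within 0.3 nM to 8 nM.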

Compound 4, half-maximal inhibitory concentration: 0.42 nM
Compound 4: middle estimate off by 3.6-fold (0.55 log units), on the high side; the range from low to high includes it.
By their numbers in this assay, from the lowest: compounds 1 and 4 (each within the scatter of the next); then compound 3; then compound 2.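

The earlier compounds shown here all kept the 1,2,3,4-tetrahydronaphthalen-1-yl group and varied only its substituents, whereas compound 4 replaces that group on the amide-type nitrogen, giving a 7.9-fold lower number from compound 2 to compound 4 (0.90 log units; beyond the scatter) in this assay. This position therefore tolerates the loss of the aromatic ring, and a six-membered non-aromatic ring with 1 hetero atom gives a stronger inhibition than the group it replaces. Nothing measured here explains the gain. The compounds shown leave open how much depends on the ring nitrogen and how much on the methyl groups. On these data alone, whether a cyclohexyl or morpholine ring on this nitrogen would perform as well also remains open.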